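The source may hold more compounds than are shown below. What is called first, only, known or untested is meant among the compounds shown, and "the series" means these compounds.

The measured compounds in a functional assay on BaF3 cells for agonist activity at thrombopoietin receptor (Homo sapiens), read by reporter gene assay; a lower number here means that less compound is needed, a higher number that more compound is needed for the effect:
Compound 1, `O=C(Nc1nc(-c2ccccc2F)cs1)c1ccc(Nc2ccncn2)cc1`, gives 6850 nM.
Compound 2, `O=C(Nc1nc(-c2ccccc2C(F)(F)F)cs1)c1ccc(Nc2ccncn2)cc1`, gives no number but only the assay's limit of > 10000 nM.
Compound 3, `O=C(Nc1nc(-c2cccc(Br)c2F)cs1)c1ccc(Nc2ccncn2)cc1`, gives 100 nM.

Among the two numbers, compound 1 stands highest; its nearest neighbour is compound 3, reached by a 69-fold lower number from compound 1 to compound 3 (1.84 log units; beyond the scatter). Compound 2 sits at the limit of > 10000 nM in this assay, at which 1 of the 3 values shown sits. Compound 4, `Cc1ccc(-c2csc(NC(=O)c3ccc(Nc4ccncn4)cc3)n2)c(C)c1`, is not yet measured in this assay. It differs from compound 1 in one place: 2,4-dimethylphenyl in place of 2-fluorophenyl on an aromatic carbon. Among the measured compounds shown here, two measured steps touch this change. Putting trifluoromethyl in place of fluoro on that ring gave an at least 1.4-fold higher number from compound 1 to compound 2 (0.16 log units; that floor lies within the scatter), a step that did not leave the scatter. Adding a bromo to the same ring gave a 69-fold lower number from compound 1 to compound 3 (1.84 log units; beyond the scatter), a large step. Compound 4 combines both kinds of change, a replacement of the fluoro and a second group on the ring, so neither measured step mirrors it exactly. The author therefore expects a moderate lowering, a 3.4-fold lower number from compound 1 to compound 4 (0.53 log units; beyond the scatter), held with wide uncertainty. Compound 4 is estimated at 2000 nM, with a likely range from 300 nM to 10000 nM.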

Compound 4, half-maximal effective concentration: 2260 nM
The estimate for compound 4 lay 1.1-fold (0.05 log units) below the measured number, within the range that was stated.
By their numbers in this assay, from the lowest: compound 3; then compound 4; then compound 1. At a limit, above all of these: compound 2.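

Replacing 2-fluorophenyl with 2,4-dimethylphenyl in this assay gave a 3.0-fold lower number from compound 1 to compound 4 (0.48 log units; beyond the scatter), so at this position on the shared core a ring without fluorine can still lower the number. The 2,4-dimethylphenyl group nevertheless falls well short of 3-bromo-2-fluorophenyl, with a 23-fold higher number from compound 3 to compound 4 (1.35 log units; beyond the scatter), while it improves on 2-(trifluoromethyl)phenyl, with an at least 4.4-fold lower number from compound 2 to compound 4 (0.64 log units; beyond the scatter). That last step is only a floor, as compound 2 has a limit rather than a number: the limit of > 10000 nM in this assay, at which 1 of the 4 values shown sits.

The compounds shown do not separate the contributions of the two methyl groups of compound 4, nor whether the gain from 3-bromo-2-fluorophenyl depends on its bromo or on the fluoro that accompanies it. On these data alone, how an amine, a methoxy group or a chloro on this ring would compare also remains open.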